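Chloro to methyl on two cores against Jurkat activation

This account rests on a few compounds, and the source may have more. Where it says the series, first, only, none or still open, it means among the compounds named here.

Measured compounds:
compound 1, `Oc1ccccc1CNc1ccc(-c2ccc(Cl)cc2)cc1`, 2390 nM
compound 2, `Cc1ccc(-c2ccc(NCc3ccccc3O)cc2)cc1`, 3790 nM
compound 3, `Oc1ccccc1CNc1ccc(-c2ccc(Cl)cc2)nc1`, reported as not active, without a number

Compound 1 and compound 2 share one core and differ only at its outer ring. In a functional assay on Jurkat cells (Homo sapiens) for activation, with a stated time of 24 h (on this read-out higher numbers stand for an effect only at larger amounts of compound and lower numbers for an effect already at smaller amounts), compound 1 gives 2390 nM, and compound 2 gives 3790 nM. The step between them, a 1.6-fold higher number from compound 1 to compound 2 (0.20 log units; within the scatter), is the change (methyl in place of chloro on an aromatic carbon). The two values lie within the scatter of each other, so nothing can be said about which of the two acts at the smaller amount.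

Compound 3 carries a different core; the difference between the two cores is not broken down here. In this assay compound 3 was reported as "not active" (no number reported), and no number was given for it.

Compound 4, `Cc1ccc(-c2ccc(NCc3ccccc3O)cn2)cc1`, is not yet measured. It stands to compound 3 as compound 2 stands to compound 1: the change (methyl in place of chloro on an aromatic carbon), the same change that was seen once before between compound 1 and compound 2, where it made a step within the scatter. Since that step was small, the same change is expected to leave compound 4 close to where compound 3 stands, and the most likely outcome is again a report without a number. Should a number be obtained, compound 4 is expected to give about 25000 nM, with a range from 8000 nM to 80000 nM.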

Compound 4, half-maximal effective concentration: "not active" (no number reported)
The entry for compound 4 holds no number, and the estimate cannot be compared.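

In this assay, compound 3 and compound 4 were both reported as not active, without a number, so no step can be read between them. No measurement shown here offers an explanation for this result. The compounds shown leave open whether the change from 4-chlorophenyl to 4-methylphenyl has any measurable size on the core shared by compound 3 and compound 4.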